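Chain-extended benzylguanidine amides in the sodium channel series

The source may hold more compounds than are shown below. What is called first, only, known or untested is meant among the compounds shown, and "the series" means these compounds.

Three amides of the shared core have numbers in an assay on CHO cells for inhibition of sodium channel protein type 2 subunit alpha (Homo sapiens); a higher number here means a weaker inhibitor, a lower number a stronger inhibitor. Compound 1 `Cc1ccc(C(=O)NC(=N)N(C)Sc2cccc(C)c2)cc1` gives 5440 nM. Compound 2 `Cc1ccc(C(=O)NC(=N)NCc2ccccc2)cc1` gives 3870 nM in this assay. Compound 3 `Cc1ccc(C(=O)NC(=N)NCCCc2ccccc2)cc1` gives 6030 nM in this assay, the highest of the three numbers, though its gap to compound 1 and its gap to compound 2 both lie within the usual scatter, so no order among the three can be read from the numbers.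

Compound 4 `Cc1ccc(C(=O)NC(=N)NCCCCCc2ccccc2)cc1` remains to be measured in this assay. It differs from compound 3 in one place: phenethyl in place of phenyl on a saturated chain carbon, three bonds along the chain from an amine nitrogen. The chain on the guanidine nitrogen is thus lengthened further. Among the compounds with values here, no measured pair in the set reports a step of this kind; compound 2 and compound 3, which carry shorter and longer chains on the same nitrogen, show numbers within the scatter of each other. On that basis no step beyond the scatter is expected from compound 3 to compound 4, and the estimated step is a 1.1-fold higher number from compound 3 to compound 4 (0.03 log units; within the scatter). Compound 4 is expected to give about 6500 nM in this assay, with a range from 2500 nM to 17000 nM.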

Compound 4, half-maximal inhibitory concentration: 2110 nM
Compound 4: middle estimate off by 3.1-fold (0.49 log units), on the high side; measured number outside the range, below it.
By their numbers in this assay, from the lowest: compounds 4, 2, 1 and 3 (each within the scatter of the next, the first and the last beyond it).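

Phenethyl in place of phenyl on a saturated chain carbon, three bonds along the chain from an amine nitrogen, gives the first step in the series that clears the scatter in this assay (a 2.9-fold lower number from compound 3 to compound 4 (0.46 log units; beyond the scatter)). This position therefore responds to further lengthening of the chain, with a modest gain in inhibition that the closely spaced earlier numbers gave no sign of. Nothing available here accounts for the size or direction of this step.

On these data alone, a single step sets no trend, so it stays open whether a still longer chain would lower the number further or reverse the change. Also open, as far as these compounds go, is whether the lower number depends on the terminal aromatic ring, or would survive with an amine or a carboxylic acid in place of it.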